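This account rests on a few compounds, and the source may have more. Where it says the series, first, only, none or still open, it means among the compounds named here.

Compound 1 `CCOC(=O)C(=O)Nc1cccc(N(C)C)c1C#N` gives 0.2 mg/kg in a functional assay on the whole organism with Rattus norvegicus as the target; on this read-out lower numbers stand for an effect already at smaller amounts and higher numbers for an effect only at larger amounts of compound. Compound 2 `CCOC(=O)C(=O)Nc1cccc(OC)c1C#N` gives 5.3 mg/kg in this assay.

Among these two numbers compound 1 stands lowest. Going by the values given here, the only measured step, a 27-fold higher number from compound 1 to compound 2 (1.42 log units; beyond the scatter), came with methoxy in place of dimethylamino on an aromatic carbon. Compound 3 `CCCCNc1cccc(NC(=O)C(=O)OCC)c1C#N` differs from compound 1 in this way: butylamino in place of dimethylamino on an aromatic carbon. The measured step bears on it only loosely, since here the nitrogen stays and only its substituents change; a small rise in this assay is expected, within or near the scatter. Compound 3 is therefore estimated at 0.5 mg/kg, in the range 0.1 mg/kg to 2.5 mg/kg. The expected step for compound 3 is a 2.5-fold higher number from compound 1 to compound 3 (0.40 log units; beyond the scatter).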

Compound 3, dose for half-maximal effect: 0.3 mg/kg
The estimate for compound 3 lay 1.7-fold (0.22 log units) above the measured number; the range from low to high includes it.
By their numbers in this assay, from the lowest: compounds 1 and 3 (each within the scatter of the next); then compound 2.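

Butylamino in place of dimethylamino on this aromatic carbon, ortho to a cyano group, gives a 1.5-fold higher number from compound 1 to compound 3 (0.18 log units; within the scatter) in this assay, so a larger nitrogen substituent carrying a hydrogen-bond donor leaves the number within the scatter. The change from methoxy gives an 18-fold lower number from compound 2 to compound 3 (1.25 log units; beyond the scatter), which places both nitrogen-linked groups well apart from the oxygen-linked one. Nothing measured here explains this separation. On these data alone, it remains open whether a free amine or a longer chain such as octylamino on this carbon would stay close to compound 1 and compound 3. As far as these compounds go, the effect of a carboxylic acid in place of the ethyl ester also remains open.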